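The compounds below may be only part of what the source reports. "The series", "measured", "known", "first", "only" and "open" are said of these compounds alone.

In a functional assay with Rattus norvegicus as the target (a higher number here means that more compound is needed for the effect, a lower number that less compound is needed), three compounds have been measured so far:

- Compound 1 `CC(C)(C)c1ccc(C/N=C(\S)NC(c2ccccc2)c2ccc(NS(C)(=O)=O)cc2)cc1`: > 100000 nM, a limit of the assay
- Compound 2 `CC[C@@H](/N=C(\S)NCc1ccc(C(C)(C)C)cc1)c1ccc(NS(C)(=O)=O)cc1`: > 100000 nM, a limit of the assay
- Compound 3 `C[C@@H](/N=C(\S)NCc1ccc(C(C)(C)C)cc1)c1ccc([N+](=O)[O-])cc1`: > 100000 nM, a limit of the assay

Within the data shown here, none of these three entries is a number, and no step between measured compounds is available. All three compounds share a single ceiling: the limit of > 100000 nM in this assay, at which 3 of the 3 values shown sit. Compound 2 therefore has no measured position of its own and stands level with the other two only in that each is reported as a limit.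

The next compound to be tested is compound 4 `CCC(/N=C(\S)NCc1ccc(C(C)(C)C)cc1)c1ccc(NS(C)(=O)=O)cc1`. The change from compound 2 is the two compounds have the same atoms and bonds; at least one stereo element is drawn with a configuration in one of them and without one in the other: 1 of 2 stereo elements differ; a stereocentre at a saturated chain carbon is drawn R in compound 2 and without a configuration in compound 4. The two compounds have the same atoms and bonds, and a stereocentre at a saturated chain carbon is drawn R in compound 2 and without a configuration in compound 4.

Among the measured compounds shown here, with no measured step to go on, no shift beyond the usual scatter is expected in this assay, and the assay will most likely report only a limit again. This expectation rests on compound 2 and its reading of > 100000 nM. The expected change is a number no higher from compound 2 to compound 4 (the limit leaves the size open). For compound 4 the estimated value is 100000 nM, with an expected range from 20000 nM to 200000 nM.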

Compound 4, half-maximal effective concentration: > 100000 nM
Compound 4: only a limit was reported (the forecaster's own chance of this, stated with the estimate: 85%); the middle value sits exactly at the limit.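

In this assay compound 4 gives > 100000 nM, a limit of the assay and not a number. Compound 2 also stands at a limit, so no step can be read between compound 2 and compound 4. The compounds shown leave open whether the configuration at the stereocentre matters for the half-maximal effective concentration, with all of them sharing one ceiling: the limit of > 100000 nM in this assay, at which 4 of the 4 values shown sit.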